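Cytotoxicity of three cyclopentanediol esters and an amide

The source may report more compounds than this note shows. Statements on the series, on what has been measured and on what is new or still open speak of the compounds shown alone.

In an ADME assay on S2 cells (Drosophila melanogaster) for cytotoxicity, read by MTT assay (on this read-out lower numbers stand for an effect already at smaller amounts and higher numbers for an effect only at larger amounts of compound), compound 1 `CCOC(=O)/C=C/[C@H]1C[C@@H](O)[C@@H](O)C1` gives > 350000 nM, which is a limit of the assay rather than a number. Compound 2 `COC(=O)/C=C/[C@H]1C[C@@H](O)[C@@H](O)C1` gives > 350000 nM, again a limit. Compound 3 `CNC(=O)/C=C/[C@H]1C[C@@H](O)[C@@H](O)C1` gives > 250000 nM, also a limit. The change from compound 2 to compound 1 is methyl in place of hydrogen on a saturated chain carbon bound to an oxygen next to a carbonyl group, and its step is a step that the two limits leave unreadable from compound 2 to compound 1. The difference between the two cores is methylamino in place of methoxy on a carbonyl carbon, and the step is a step that the two limits leave unreadable from compound 2 to compound 3. Among the measured compounds shown here, compound 4 `CCNC(=O)/C=C/[C@H]1C[C@@H](O)[C@@H](O)C1` differs from compound 3 by methyl in place of hydrogen on a saturated chain carbon bound to an amide-type nitrogen; this is the same kind of change as the one from compound 2 to compound 1, but the place differs, on a saturated chain carbon bound to an oxygen next to a carbonyl group in the one case and on a saturated chain carbon bound to an amide-type nitrogen in the other. Compound 4 is expected to show a step that the limit leaves unreadable from compound 3 to compound 4, resting on compound 3 sitting at > 250000 nM in this assay. The estimate for compound 4 in this assay is therefore 400000 nM, with a range from 150000 nM to 1000000 nM.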

Compound 4, half-maximal effective concentration: > 250000 nM
Compound 4 ended at the assay's limit; the forecaster's own chance of this, stated with the estimate: 85%; the middle value is on the limit's open side.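

In this assay, compound 4 ends at a limit rather than a number, as do compound 1, compound 2 and compound 3, so no step among these compounds can be read. The compounds shown leave open at what concentration any of them would affect the cells, and whether methyl in place of hydrogen changes that concentration at all.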